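Aryl Sulfonamide Diamines: From Compound 1 Toward Compound 4

The compounds below may be only part of what the source reports. "The series", "measured", "known", "first", "only" and "open" are said of these compounds alone.

Measured compounds:
Compound 1, `CC(C)(C)c1ccc(CNCCCNS(=O)(=O)c2cc(C(F)(F)F)cc(C(F)(F)F)c2)cc1`: 2300 nM
Compound 2, `O=S(=O)(NCCNCc1ccc(-c2ccccc2)cc1)c1cc(C(F)(F)F)cc(C(F)(F)F)c1`: 2700 nM
Compound 3, `O=S(=O)(NCCCCCCNCc1ccc(Br)cc1)c1cccc(C(F)(F)F)c1`: 5970 nM

The three measured compounds were tested in a functional assay on MIA PaCa-2 cells (Homo sapiens) for inhibition, read by MTT assay, with a stated time of 72 h; on this read-out higher numbers stand for weaker inhibition of growth and lower numbers for stronger inhibition of growth. Compound 1 gives the lowest of the three numbers, at 2300 nM. Compound 2 sits nearest, with a number within the scatter of that of compound 1, so the two cannot be told apart on these data. Compound 3 stands furthest away, with a number beyond the scatter, so it inhibits growth less strongly than compound 1. No pair among these three differs in a single place, so no single-point step can be read from them.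

Compound 4, `COc1cccc(CNCCCNS(=O)(=O)c2cc(C(F)(F)F)cc(C(F)(F)F)c2)c1`, has not yet been measured in this assay. Its relation to compound 1 is a single change: 3-methoxyphenyl in place of 4-(tert-butyl)phenyl on a saturated chain carbon bound to an amine nitrogen.

Going by the values given here, nothing among the measured compounds speaks directly to this change, since none of them carries a 3-methoxyphenyl group. With all three measured numbers falling in a narrow band, the expected step from compound 1 to compound 4 is a modest one, a 1.7-fold higher number from compound 1 to compound 4 (0.24 log units; within the scatter), toward weaker inhibition of growth, and it may not reach beyond the scatter. Compound 4 is therefore estimated at 4000 nM in this assay, with a range from 1500 nM to 11000 nM.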

Compound 4, concentration for 50% growth inhibition: 3400 nM
Estimate against measurement, compound 4: 1.2-fold (0.07 log units) above; low and high end bracket the measured number.
By their numbers in this assay, from the lowest: compounds 1, 2, 4 and 3 (each within the scatter of the next, the first and the last beyond it).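

In this assay, 3-methoxyphenyl in place of 4-(tert-butyl)phenyl on a saturated chain carbon bound to an amine nitrogen gives a 1.5-fold higher number from compound 1 to compound 4 (0.17 log units; within the scatter), so the two compounds cannot be told apart on these data. Going by these compounds alone, this is the first step here that can be read at a single place, which the earlier compounds could not offer, and it shows that this place accepts an exchange of a group of 10 heavy atoms, all carbon, for one of 8 heavy atoms, with an oxygen and a hydrogen-bond acceptor, without a difference beyond the scatter. No measurement among those shown offers an explanation for this result.

As far as these compounds go, whether the same holds for other groups at this place stays open, for instance a plain phenyl or a cyclohexyl group, or a carboxylic acid in place of the methoxy group on the ring. Also open, from the compounds shown here alone, is what a longer chain would do in the core of compound 1, taken on its own, with both aryl groups kept as they are.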